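The source may hold more compounds than are shown below. What is called first, only, known or untested is meant among the compounds shown, and "the series" means these compounds.

Compound 1 `Cc1cc(C(=O)Nc2nn[nH]n2)nc(-c2ccccc2)c1` was tested in a functional assay on the whole organism with Rattus norvegicus as the target, at a dose of 3 mg/kg by the oral route (on this read-out higher numbers stand for a stronger effect at the one dose given and lower numbers for a weaker effect), where compound 1 gives 50%. For the measured compounds named here, of the two compounds measured so far, compound 1 stands lowest. The other one is compound 2 `Cc1cccc(-c2cc(C)cc(C(=O)Nc3nn[nH]n3)n2)c1`, which carries a methyl in place of hydrogen on an aromatic carbon; in this assay compound 2 gives 61%, a step of a number 11 percentage points higher from compound 1 to compound 2 (beyond the scatter).

The compound now waiting for its number is compound 3 `CCCCc1ccc(-c2cc(C)cc(C(=O)Nc3nn[nH]n3)n2)cc1`, which differs from compound 1 in one place: butyl in place of hydrogen on an aromatic carbon. Going by the values given here, the only measured step that bears on this is the one from compound 1 to compound 2, where a small alkyl group added to the same ring brought a modest gain. Among the compounds with values here, a butyl is a longer chain than a methyl, and no measured pair shows what such a chain does here, so the expected step is small and uncertain. For compound 3 the expected value in this assay is 55%, with a range from 30% to 78%, corresponding to an expected step of a number 5 percentage points higher from compound 1 to compound 3 (within the scatter).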

Compound 3, a percentage reported as inhibition, in the whole organism at one dose (the size of the read-out at that dose, not a potency): 67%
Compound 3: the middle estimate sits 12 percentage points below what was measured; the range from low to high includes it.
By their numbers in this assay, from the lowest: compound 1; then compounds 2 and 3 (each within the scatter of the next).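

In this assay, a butyl on an aromatic carbon of the six-membered aromatic ring of carbon only, para to a large group, gives a step of a number 17 percentage points higher from compound 1 to compound 3 (beyond the scatter). Until now the only substituent seen added to compound 1 was a methyl, so this result adds that a longer open chain, with no ring and no hydrogen-bond donors or acceptors, can sit at this position and still go with a stronger effect at the one dose given. Nothing available explains why the butyl goes with this higher number.

Still open, on these data alone, is how far this trend runs: whether a longer chain such as hexyl, or a butyl ending in an amine or a carboxylic acid, would hold or lose the effect here. As far as these compounds go, the read-out also covers a single dose, so how these compounds compare in potency remains unknown.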